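The source may report more compounds than this note shows. Statements on the series, on what has been measured and on what is new or still open speak of the compounds shown alone.

Measured compounds in an assay on cells for inhibition of Amine oxidase [flavin-containing] B (Homo sapiens), read by fluorescence and Amplex Red, with stated times of 30 min and 15 min; on this read-out higher numbers stand for weaker inhibition and lower numbers for stronger inhibition:
- compound 1, `C#CCNC1CCc2c(NCc3ccccc3)cccc21`: > 20000 nM; this value is a limit of the assay, not a number.
- compound 2, `C#CCNC1CCc2c(NCc3cccc(C)c3)cccc21`: 710 nM
- compound 3, `C#CCNC1CCc2c(OCCc3cc(NC(C)=O)ccc3Cl)cccc21`: 590 nM

Compound 3 holds the lowest of the two numbers in this assay; the gap to compound 2 lies within the scatter, so no order between them is claimed.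

Compound 4, `C#CCNC1CCc2c(OCCc3cc(NC(=O)c4cccc(F)c4)ccc3Cl)cccc21`, differs from compound 3 by 3-fluorophenyl in place of methyl on a carbonyl carbon.

Among the measured compounds shown here, the single measured step, an at least 28-fold lower number from compound 1 to compound 2 (1.44 log units; beyond the scatter), concerns a methyl added on an aromatic carbon and does not touch the carbonyl carbon changed here, so it gives no direct guide. For the measured compounds named here, no measured step bears on the present change, and a step within the scatter is therefore expected, a 1.0-fold higher number from compound 3 to compound 4 (0.01 log units; within the scatter).

Compound 4 is estimated at 600 nM, between 200 nM and 2000 nM in this assay.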

Compound 4, half-maximal inhibitory concentration: > 20000 nM
Compound 4: no number, only a limit; the forecaster's own chance of this, stated with the estimate: 5%; middle value at least 33-fold (1.52 log units) away from the limit.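

In this assay the carbonyl carbon of the acetamido group proves sensitive to change, with an at least 33-fold higher number from compound 3 to compound 4 (1.53 log units; beyond the scatter) for 3-fluorophenyl in place of methyl. Compound 4 gives > 20000 nM, a limit of the assay and not a number. Compound 4 thus sits at the same limit as compound 1: the limit of > 20000 nM in this assay, at which 2 of the 4 values shown sit.

Open, going by these compounds, is whether ethyl or an unsubstituted phenyl on this carbonyl carbon would stay close to compound 3. Also open, on these data alone, is whether the aromatic ring or its fluorine carries the step.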